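The source may hold more compounds than are shown below. What is called first, only, known or untested is meant among the compounds shown, and "the series" means these compounds.

Compound 1 `CC(C)(C)OC(=O)/C=C/c1ccc2c(c1)C(=O)C(=O)N2Cc1ccc(Br)cc1`: 2050 nM
Compound 2 `COc1ccc(CN2C(=O)C(=O)c3cc(/C=C/C(=O)OC(C)(C)C)ccc32)cc1`: 620 nM

Both values come from a functional assay on HepG2 cells (Homo sapiens) for cytotoxicity, read by MTT assay, with a stated time of 48 h (on this read-out lower numbers stand for stronger inhibition and higher numbers for weaker inhibition), and compound 1 holds the higher of the two numbers. Among the measured compounds shown here, the only measured step, a 3.3-fold lower number from compound 1 to compound 2 (0.52 log units; beyond the scatter), came with methoxy in place of bromo on an aromatic carbon.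

Compound 3 `O=C1C(=O)N(Cc2ccc(Br)cc2)c2ccc(/C=C/C(=O)N3CCCC3)cc21` keeps the bromo group of compound 1 and changes another place instead, with pyrrolidin-1-yl in place of tert-butoxy on a carbonyl carbon. For the measured compounds named here, no measured compound varies this place, so the step of a 3.3-fold lower number from compound 1 to compound 2 (0.52 log units; beyond the scatter) bears on it only loosely. It suggests how large a single change can be in this assay, but it gives no direction here. A modest move towards a higher number is expected, though this lean is a tentative guess. The expected step is a 1.5-fold higher number from compound 1 to compound 3 (0.17 log units; within the scatter). For compound 3 the estimated value is 3000 nM, with an expected range from 800 nM to 12000 nM.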

Compound 3, half-maximal inhibitory concentration: 6300 nM
The estimate for compound 3 lay 2.1-fold (0.32 log units) below the measured number; the measured number falls inside the stated range.
By their numbers in this assay, from the lowest: compound 2; then compound 1; then compound 3.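

Among the compounds shown here, this is the first look at the group on the carbonyl carbon. In this assay the change from tert-butoxy to pyrrolidin-1-yl gives a 3.1-fold higher number from compound 1 to compound 3 (0.49 log units; beyond the scatter), so this place does affect the number, and here the move is towards weaker inhibition. Both groups have the same heavy-atom count, which shows that matching that count does not guarantee a matching result, and nothing measured here explains the rise.

For the compounds shown here, the pyrrolidin-1-yl step is seen only with the bromo group, so its size with methoxy in place of bromo remains open. The compounds shown also leave open how a carboxylic acid, a diethylamino group or a morpholin-4-yl group would behave on this carbonyl carbon.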